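The compounds below may be only part of what the source reports. "The series", "measured", "known", "first", "only" and "open" are said of these compounds alone.

Working notes on the series. The shared core is held fixed; the variation sits on the terminal six-membered aromatic ring. Compound 1 `COc1cc(OCc2csc(-c3ccc(C(N)=O)cc3)n2)c2cc(-c3cn4nc(OC)sc4n3)oc2c1` gives 0.3 nM in a functional assay on HEK293 cells for antagonist activity at proteinase-activated receptor 4 (Homo sapiens), read by FLIPR and calcium flux, with a stated time of 30 min; on this read-out lower numbers stand for stronger inhibition and higher numbers for weaker inhibition. Compound 2 `COc1cc(OCc2csc(-c3ccc(S(C)(=O)=O)cc3)n2)c2cc(-c3cn4nc(OC)sc4n3)oc2c1` gives 0.8 nM. Compound 3 `COc1cc(OCc2csc(-c3ccc(C(=O)O)cc3)n2)c2cc(-c3cn4nc(OC)sc4n3)oc2c1` gives 1.1 nM, the highest of the three numbers; its neighbours are a 1.4-fold higher number from compound 2 to compound 3 (0.14 log units; within the scatter) and a 3.7-fold higher number from compound 1 to compound 3 (0.56 log units; beyond the scatter). Also measured: a 2.7-fold higher number from compound 1 to compound 2 (0.43 log units; beyond the scatter).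

Compound 4 `COc1cc(OCc2csc(-c3ccccc3)n2)c2cc(-c3cn4nc(OC)sc4n3)oc2c1` is unmeasured. It differs from compound 3 by hydrogen in place of carboxy on an aromatic carbon, on an aromatic carbon of a six-membered aromatic ring of carbon only, para to a large group; cut one bond further out, 4-carboxyphenyl becomes phenyl. Within the data shown here, no measured step removes the group from this position entirely; the steps that bear on it only exchange one group for another, and those exchanges moved the number by modest amounts at most. Loss of the whole group is a larger change than any shown, so a further rise in the number is expected, of moderate size. Compound 4 is expected at 4 nM, with a range of 1 nM to 15 nM, which means an expected step of a 3.6-fold higher number from compound 3 to compound 4 (0.56 log units; beyond the scatter).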

Compound 4, half-maximal inhibitory concentration: 0.3 nM
For compound 4 the middle estimate is 13-fold (1.12 log units) above the measured one, outside the stated range (below it).
By their numbers in this assay, from the lowest: compounds 1 and 4 (each within the scatter of the next); then compounds 2 and 3 (each within the scatter of the next).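

With the group gone altogether, the position still reads well in this assay: there is a 3.7-fold lower number from compound 3 to compound 4 (0.56 log units; beyond the scatter) and a 2.7-fold lower number from compound 2 to compound 4 (0.43 log units; beyond the scatter), so neither carboxy nor methylsulfonyl is needed here for strong inhibition, and both compounds carrying them sit on the weaker side of the unsubstituted phenyl. Against the carbamoyl compound the same change gives no change at the digits printed from compound 1 to compound 4 (within the scatter), so within these four compounds a bare phenyl serves as well as the best substituted ring, and no group shown improves on hydrogen. Nothing available explains why the carboxy and methylsulfonyl compounds read weaker than the hydrogen compound. The compounds shown leave open how a small group such as fluorine or methyl, or a basic one such as an amine, would read at this position. They also leave open whether hydrogen would match carbamoyl on a different core.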